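Aryl amide swap in a small agonist series

This account rests on a few compounds, and the source may have more. Where it says the series, first, only, none or still open, it means among the compounds named here.

Of the compounds shown here, two have been read in a functional assay on HEK293 cells for agonist activity at D(4) dopamine receptor (Homo sapiens), read by FLIPR (on this read-out lower numbers stand for smaller maximal responses and higher numbers for larger maximal responses), so far. Compound 1 `Cc1ccc(C(=O)NCN2CCC(c3cccc[n+]3[O-])CC2)cc1C` gives 65% in this assay. Compound 2 `O=C(CN1CCC(c2cccc[n+]2[O-])CC1)Nc1ccc(F)cc1F` gives 74% in this assay, the higher of the two numbers, though its gap to compound 1 is within the usual scatter, so no order between the two can be claimed. Among the compounds with values here, both share the same core and differ in the amide-bearing part, but no single-point step between measured compounds exists, so nothing is yet known about how a change at the amide-type nitrogen moves the maximal response.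

Compound 3 `O=C(CN1CCC(c2cccc[n+]2[O-])CC1)Nc1cccc(Cl)c1Cl` is the next entry and is not yet measured. It differs from compound 2 in one place: 2,3-dichlorophenyl in place of 2,4-difluorophenyl on an amide-type nitrogen. Within the data shown here, no measured step covers a swap of this kind, so the step is expected to stay within the scatter, in either direction; the expected step is a number 4 percentage points lower from compound 2 to compound 3 (within the scatter). Compound 3 is expected to give about 70% in this assay, with a range from 50% to 90%.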

Compound 3, largest response reached (reported as efficacy), in percent of the reference or control that the assay uses: 66%
For compound 3 the middle estimate is 4 percentage points above the measured one; measured number inside the range.
By their numbers in this assay, from the lowest: compounds 1, 3 and 2 (each within the scatter of the next).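

Placing 2,3-dichlorophenyl in place of 2,4-difluorophenyl on the amide-type nitrogen provides the first single-place step in the series: in this assay, the step is a number 8 percentage points lower from compound 2 to compound 3 (within the scatter), so no change in maximal response can be claimed for this exchange. At this position, the two dihalophenyl groups therefore cannot be told apart by this read-out, although the exchange alters both the halogen and its placement on the aromatic ring, and this single step cannot separate those two changes. No supporting data bear on this result, so it stands as an observation without an assigned cause.

Still open, from the compounds shown here alone, is whether any group on this nitrogen can move the maximal response beyond the scatter, for example an unsubstituted phenyl, a benzyl group or a longer alkyl chain in place of the dihalophenyl ring. Within the data shown here, also open is how compound 1, which differs from compound 2 and compound 3 in more than one place, connects to them, since no single-place step links it to either.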